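A few compounds are considered here, and "the series" means these few. Any claim that something is new, unique, unknown or untested is made for them only; others in the source may bear on it.

Compound 3 `CC1CCN(c2c(S(=O)(=O)c3ccc(F)c(F)c3)cnc3cc(Cl)ccc23)CC1` gives 90% in an assay on isolated protein for displacement of a labelled ligand from metabotropic glutamate receptor 5 (Homo sapiens), with a stated time of 60 min, tested at 1 uM (a higher number here means more inhibition at the concentration tested (going by the name of the read-out), a lower number less inhibition), the second highest of the three numbers recorded so far. Its nearest neighbour is compound 1 `CC1CCN(c2c(S(=O)(=O)c3ccc(F)cc3)cnc3cc(Cl)ccc23)CC1` with 91%, and the step of a number 1 percentage points lower from compound 1 to compound 3 (within the scatter) lies within the scatter. Compound 2 `Cc1ccc(S(=O)(=O)c2cnc3cc(Cl)ccc3c2N2CCC(C)CC2)cc1C` gives 86%, and the step of a number 4 percentage points higher from compound 2 to compound 3 (within the scatter) also lies within the scatter.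

Compound 4 `COc1cccc(S(=O)(=O)c2cnc3cc(Cl)ccc3c2N2CCC(C)CC2)c1` differs from compound 3 in one place: 3-methoxyphenyl in place of 3,4-difluorophenyl on a sulfonyl sulfur. Two earlier steps swap the aryl group on the same sulfonyl sulfur: a number 5 percentage points lower from compound 1 to compound 2 (within the scatter) and a number 4 percentage points higher from compound 2 to compound 3 (within the scatter), each within the scatter. For this assay the expected step is therefore a number 2 percentage points lower from compound 3 to compound 4 (within the scatter), with no change beyond the scatter. Compound 4 is thus estimated at 88%, in a range from 77% to 96%.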

Compound 4, a percentage reported as inhibition, at one concentration (the size of the read-out at that concentration, not a potency): 93%
The estimate for compound 4 lay 5 percentage points below the measured number; measured number inside the range.
By their numbers in this assay, from the lowest: compounds 2, 3, 1 and 4 (each within the scatter of the next).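

In this assay, 3-methoxyphenyl on the sulfonyl sulfur brings in oxygen and a hydrogen-bond acceptor, yet all three new steps stay within the scatter: a number 3 percentage points higher from compound 3 to compound 4 (within the scatter), a number 7 percentage points higher from compound 2 to compound 4 (within the scatter) and a number 2 percentage points higher from compound 1 to compound 4 (within the scatter). Among these four compounds, this position therefore accepts a methoxy-bearing aryl group as well as the fluorinated and methylated ones, with no change that can be told apart. Nothing measured here offers an explanation for this result.

On these data alone, whether an amine or a carboxylic acid on the phenyl ring, or a longer alkyl chain in its place, would keep the number stays open. Readings at a single concentration also leave open whether these compounds differ in potency.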